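This account rests on a few compounds, and the source may have more. Where it says the series, first, only, none or still open, it means among the compounds named here.

- Compound 1 `CCN1CCN(c2ncc3c(n2)CCN(C(=O)c2cc(Cc4n[nH]c(=O)c5ccccc45)ccc2F)C3)CC1` gives 137000 nM
- Compound 2 `CN(C)CCN(C)c1ncc2c(n1)CCN(C(=O)c1cc(Cc3n[nH]c(=O)c4ccccc34)ccc1F)C2` gives > 200000 nM (a limit)
- Compound 3 `CCCN(CCC)c1ncc2c(n1)CCN(C(=O)c1cc(Cc3n[nH]c(=O)c4ccccc34)ccc1F)C2` is not yet measured

Among the measured compounds shown here, in a functional assay on HCC1937 cells (Homo sapiens) for inhibition, read by MTT assay, with a stated time of 48 h (on this read-out higher numbers stand for weaker inhibition and lower numbers for stronger inhibition), compound 1 gives 137000 nM as the only actual number so far. Compound 2 gives > 200000 nM and this is a limit of the assay, not a number.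

Compound 3 carries dipropylamino in place of 4-ethylpiperazin-1-yl on an aromatic carbon of the shared core, and the count of that difference is dipropylamino in place of 4-ethylpiperazin-1-yl on an aromatic carbon.

For the measured compounds named here, one measured step bears on this change, since it replaces 4-ethylpiperazin-1-yl on an aromatic carbon too. Going by the values given here, with an at least 1.4-fold higher number from compound 1 to compound 2 (0.16 log units; that floor lies within the scatter) as the only guide, and its floor within the scatter, no clear direction is expected in this assay and no step beyond the scatter. The expected step is a 1.2-fold higher number from compound 1 to compound 3 (0.09 log units; within the scatter) as estimated here. For compound 3 the estimated value is 170000 nM with an expected range from 90000 nM to 300000 nM, and the assay may report only a limit.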

Compound 3, half-maximal inhibitory concentration: 20300 nM
Beside the measured number, compound 3's estimate is 8.4-fold (0.92 log units) above it; measured number outside the range, below it.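

At this position, on an aromatic carbon between two ring nitrogen atoms, the choice of amine can shift the result well beyond the scatter, which the earlier pair could not show: in this assay, the change to dipropylamino gives a 6.7-fold lower number from compound 1 to compound 3 (0.83 log units; beyond the scatter). Removing the ring of 4-ethylpiperazin-1-yl is not enough on its own, since the open-chain (2-(dimethylamino)ethyl)(methyl)amino group does not match dipropylamino, with an at least 9.8-fold lower number from compound 2 to compound 3 (0.99 log units; beyond the scatter). That second step is only a floor, since the result for compound 2 is a limit of the assay and not a number: the limit of > 200000 nM in this assay, at which 1 of the 3 values shown sits.

Whether the gain follows the length of the two propyl chains remains open, and these compounds do not explain it. A diethylamino or dibutylamino group on the same carbon would help to answer that question.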